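This account rests on a few compounds, and the source may have more. Where it says the series, first, only, none or still open, it means among the compounds named here.

Series notes. The shared core of compound 1 `CON[C@]1(CCC(C)C)C(=O)C(C2=NS(=O)(=O)c3cc(NS(C)(=O)=O)ccc3N2)=C(O)c2ccccc21` carries a methoxy on the amine nitrogen; in an in vivo ADME assay on the whole organism (strain Sprague-Dawley) for pharmacokinetics, with Rattus norvegicus as the target, at a dose of 5 mg/kg by the intravenous route (a lower number here means slower removal, a higher number faster removal of the compound), compound 1 gives 45 mL/min/kg. Compound 2 `CC(C)CC[C@@]1(NCc2ccccc2)C(=O)C(C2=NS(=O)(=O)c3cc(NS(C)(=O)=O)ccc3N2)=C(O)c2ccccc21` carries a benzyl there instead, and in this assay compound 2 gives 19.3 mL/min/kg. Compound 3 `CC(C)(C)CCC1(NCc2ccc3ccccc3c2)C(=O)C(C2=NS(=O)(=O)c3cc(NS(C)(=O)=O)ccc3N2)=C(O)c2ccccc21` gives 23.3 mL/min/kg in this assay. Compound 2 thus shows the lowest of the three numbers; its value and that of compound 3 lie within the scatter of each other, while against compound 1 the gap is beyond the scatter, as a 2.3-fold lower number from compound 1 to compound 2 (0.37 log units; beyond the scatter) shows.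

Compound 4 `CC(C)CC[C@@]1(NS(C)(=O)=O)C(=O)C(C2=NS(=O)(=O)c3cc(NS(C)(=O)=O)ccc3N2)=C(O)c2ccccc21` is the next compound. Its difference from compound 2 is methylsulfonyl in place of benzyl on an amine nitrogen. For the measured compounds named here, the only measured step at this position is a 2.3-fold lower number from compound 1 to compound 2 (0.37 log units; beyond the scatter), where the larger group on the amine nitrogen went with a lower number; compound 4 goes the other way, exchanging that group for a smaller one. Going by the values given here, no measured pair shows methylsulfonyl at this position, so the direction rests on that single step. A modest rise back toward the level of compound 1 is expected, a 1.6-fold higher number from compound 2 to compound 4 (0.19 log units; within the scatter), though a number within the scatter of compound 2 would not be surprising. Compound 4 is therefore estimated at 30 mL/min/kg in this assay, with a range from 15 mL/min/kg to 60 mL/min/kg.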

Compound 4, clearance: 71.7 mL/min/kg
Compound 4: middle estimate off by 2.4-fold (0.38 log units), on the low side; measured number outside the range, above it.
By their numbers in this assay, from the lowest: compounds 2, 3, 1 and 4 (each within the scatter of the next, the first and the last beyond it).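

The change from benzyl to methylsulfonyl on the amine nitrogen gives a clear move in this assay (a 3.7-fold higher number from compound 2 to compound 4 (0.57 log units; beyond the scatter)), so this position now has two steps beyond the scatter, and in both of them the compound with benzyl has the lower number. Methylsulfonyl and methoxy are not separated at this position (a 1.6-fold higher number from compound 1 to compound 4 (0.20 log units; within the scatter)), so among these three groups only benzyl stands apart, and it is also the only one of the three with an aromatic ring, although that match alone does not establish any link to the read-out. Nothing available here explains why benzyl differs from the other two groups, and no supporting data bear on the result.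

Still open, going by these compounds, is whether the lower number goes with the aromatic ring of benzyl or with a plain carbon chain on the amine nitrogen, a question that a cyclohexylmethyl or an ethyl group there, set against the free amine, could address. For the compounds shown here, compound 3 differs from compound 2 in more than one place, so it gives no clean step on this question, and it remains unknown how a longer chain such as phenethyl would behave at this position.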